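The source may hold more compounds than are shown below. What is called first, only, known or untested is meant among the compounds shown, and "the series" means these compounds.

In an ADME assay on MT4 cells (Homo sapiens) for cytotoxicity, read by MTT assay, with a stated time of 5 days (on this read-out higher numbers stand for lower toxicity in this test and lower numbers for higher toxicity in this test), compound 1 `CCCCNc1cc(Oc2c(OC)cc3cc(C#N)ccc3c2OC)nc(Nc2ccc(C#N)cc2)n1` gives > 125000 nM as a limit of the assay, not a number. Compound 2 `COc1cc2cc(C#N)ccc2c(OC)c1Oc1cc(NCC(C)C)nc(Nc2ccc(C#N)cc2)n1` gives > 125000 nM as a limit too. Compound 3 `COc1cc2cc(C#N)ccc2c(OC)c1Oc1cc(NCC2CCOCC2)nc(Nc2ccc(C#N)cc2)n1` likewise gives only a limit, > 125000 nM in this case. All three thus sit at the limit of > 125000 nM in this assay, at which 3 of the 3 values shown sit, without a readable number. Compound 4 `COc1cc2cc(C#N)ccc2c(OC)c1Oc1cc(NC2CCOC2)nc(Nc2ccc(C#N)cc2)n1` carries oxolan-3-yl in place of (oxan-4-yl)methyl on a nitrogen on an aromatic ring. The nearest measured changes are a step that the two limits leave unreadable from compound 1 to compound 2 and a step that the two limits leave unreadable from compound 1 to compound 3 and a step that the two limits leave unreadable from compound 2 to compound 3 on the same nitrogen, and none has a size that can be read. Because of the limit of > 125000 nM in this assay, at which 3 of the 3 values shown sit, no shift beyond the scatter is expected in this assay in either direction. The expected change is a number no higher from compound 3 to compound 4 (the limit leaves the size open) with no direction to it. Compound 4 is expected at 125000 nM with an estimated range from 60000 nM to 250000 nM and will probably return a limit again.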

Compound 4, half-maximal cytotoxic concentration: > 125000 nM
Compound 4 ended at the assay's limit; the forecaster's own chance of this, stated with the estimate: 85%; the middle value sits exactly at the limit.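

Among the compounds shown here, no step among compound 1, compound 2, compound 3 and compound 4 can be read, since each gives only a limit: the limit of > 125000 nM in this assay, at which 4 of the 4 values shown sit. The compounds shown leave open whether any group on this nitrogen would give a readable number in this assay.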